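Removing the aryl group from the triazole of compound 2

A few compounds are considered here, and "the series" means these few. Any claim that something is new, unique, unknown or untested is made for them only; others in the source may bear on it.

Going by the values given here, compound 2 `CCCCCc1ccc(-c2cn(C[C@H](O)[C@H]3OC(=O)C(OCc4ccccc4)=C3OCc3ccccc3)nn2)cc1` is the only compound here with a numerical result: in a functional assay on HCT-116 cells (Homo sapiens) for antiproliferative activity, read by MTT assay, with a stated time of 72 h (a higher number here means a weaker inhibitor, a lower number a stronger inhibitor), compound 2 gives 13800 nM. Compound 1 `COc1ccccc1-c1cn(C[C@H](O)[C@H]2OC(=O)C(OCc3ccccc3)=C2OCc2ccccc2)nn1` reaches only a limit of this assay, not a number; compound 1 gives > 100000 nM, a limit at which one of the two values sits (the limit of > 100000 nM in this assay, at which 1 of the 2 values shown sits). Compound 3 `O=C1O[C@H]([C@@H](O)Cn2ccnn2)C(OCc2ccccc2)=C1OCc1ccccc1` has not yet been measured. It differs from compound 2 in one place: hydrogen in place of 4-pentylphenyl on an aromatic carbon.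

Among the compounds with values here, the one measured step bears on this indirectly. It went an at least 7.2-fold lower number from compound 1 to compound 2 (0.86 log units; beyond the scatter), showing that the aryl group on the triazole matters for this assay, since a change within it moved the number beyond the scatter. Compound 3 keeps no aryl group at all there. Within the data shown here, with only two compounds, the direction of removing the group entirely cannot be read off directly, but the loss of the whole 4-pentylphenyl is a larger change than the swap between compound 1 and compound 2.

The expectation is therefore a weaker inhibitor: the step from compound 2 to compound 3 is estimated as a 4.3-fold higher number from compound 2 to compound 3 (0.64 log units; beyond the scatter). Compound 3 is expected to give about 60000 nM, between 20000 nM and 150000 nM, with a fair chance that only a limit is reached.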

Compound 3, half-maximal inhibitory concentration: > 100000 nM
Compound 3: a limit, no number; the forecaster's own chance of this, stated with the estimate: 45%; at least 1.6-fold (0.22 log units) between middle value and limit.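

On the aromatic carbon of the five-membered aromatic ring, replacing 4-pentylphenyl with hydrogen gives an at least 7.2-fold higher number from compound 2 to compound 3 (0.86 log units; beyond the scatter) in this assay, so removing this group entirely costs measurable activity. Compound 3 gives > 100000 nM, which is a limit and not a number. The step from compound 1 to compound 3 cannot be read, so the 2-methoxyphenyl group of compound 1 shows no readable gain over hydrogen, and having a six-membered aromatic ring of carbon only at this position is not enough on its own to give a number here: the limit of > 100000 nM in this assay, at which 2 of the 3 values shown sit.

The compounds shown leave open whether the pentyl chain, the ring that carries it, or both together account for the number given by compound 2. An unsubstituted phenyl group or a pentyl chain set directly on the same aromatic carbon would help separate these parts, and a longer chain such as octyl would show whether the number in this assay keeps falling as the chain grows.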